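Swapping 2-chlorophenyl for 4-bromophenyl

The compounds below may be only part of what the source reports. "The series", "measured", "known", "first", "only" and "open" are said of these compounds alone.

compound 1 `COc1cccc(/C=C2\CCC/C(=C\c3ccccc3Br)C2=O)c1OC` gives 12100 nM
compound 2 `COc1cccc(/C=C2\CCC/C(=C\c3cccc(OC)c3OC)C2=O)c1` gives 7000 nM
compound 3 `COc1ccc(/C=C2\CCC/C(=C\c3ccccc3Cl)C2=O)cc1OC` gives 7100 nM

These three numbers come from a functional assay on SW-620 cells (Homo sapiens) for cytotoxicity, read by MTT assay, with a stated time of 72 h (on this read-out lower numbers stand for stronger inhibition and higher numbers for weaker inhibition), and all lie within the scatter of one another, so compound 3, at 7100 nM, stands level with both of the others. Compound 4 `COc1ccc(/C=C2\CCC/C(=C\c3ccc(Br)cc3)C2=O)cc1OC` has not yet been measured in this assay and departs from compound 3 in one place: 4-bromophenyl in place of 2-chlorophenyl on a double-bonded chain carbon bound to a double-bonded ring carbon. Going by the values given here, no measured compound carries 4-bromophenyl, so the evidence for this change is indirect. Among the compounds with values here, the one measured step that bears on it, a 1.7-fold lower number from compound 1 to compound 2 (0.24 log units; within the scatter), puts 3-methoxyphenyl in place of 2-bromophenyl at the same kind of place. That step is small, so no shift beyond the scatter is expected here either, though a single step is thin support. The estimated change, a 1.1-fold lower number from compound 3 to compound 4 (0.04 log units; within the scatter), is expected to stay within the scatter. For compound 4 the estimate is 6500 nM, with an expected range from 2500 nM to 16000 nM, until a measurement settles it.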

Compound 4, half-maximal inhibitory concentration: 5200 nM
The estimate for compound 4 lay 1.3-fold (0.10 log units) above the measured number, within the range that was stated.
By their numbers in this assay, from the lowest: compounds 4, 2, 3 and 1 (each within the scatter of the next, the first and the last beyond it).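

In this assay, placing 4-bromophenyl in place of 2-chlorophenyl on a double-bonded chain carbon bound to a double-bonded ring carbon gives a 1.4-fold lower number from compound 3 to compound 4 (0.14 log units; within the scatter). Going by these compounds alone, this is the first step read directly on the core of compound 3, and it shows that changing both the halogen and its place on the phenyl ring together produces no shift that can be told from the scatter. The data shown offer no measurement that could account for this result.

At this place the compounds shown carry only halogen-bearing and methoxy-bearing phenyl groups, so it remains open whether an amine or a carboxylic acid there would move the number beyond the scatter. The step also changes the halogen and its ring place at once, so the contribution of each remains unresolved.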